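The compounds below may be only part of what the source reports. "The series", "measured", "known", "first", "only" and "open" are said of these compounds alone.

Compound 1, `Cc1c(O)ccc2c1[C@H](Cn1cc(-c3ccc(F)cc3)nn1)[C@@]13CC(=O)[C@@](C)(CC[C@@H]21)C3`, in a functional assay on SW480 cells (Homo sapiens) for cytotoxicity, read by MTT assay, with a stated time of 4 days (a lower number here means a stronger inhibitor, a higher number a weaker inhibitor), gives > 20000 nM, which is a limit of the assay and not a number.
Compound 2, `Cc1c(O)ccc2c1[C@H](Cn1cc(-c3ccc(C(F)(F)F)cc3)nn1)[C@@]13CC(=O)[C@@](C)(CC[C@@H]21)C3`, in this assay gives > 20000 nM, again only a limit.
Compound 3, `C=C1C[C@]23C[C@@]1(O)CC[C@@H]2c1cccc(C)c1[C@@H]3Cn1cc(-c2ccc(F)cc2)nn1`, in this assay gives > 20000 nM, also only a limit.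

Compound 2 carries trifluoromethyl in place of fluoro on an aromatic carbon relative to compound 1. The step that the two limits leave unreadable from compound 1 to compound 2 cannot be read, since both values are limits. Compound 3 has a different core from compound 1; the difference between the two cores is not broken down here. Compound 4, `C=C1C[C@]23C[C@@]1(O)CC[C@@H]2c1cccc(C)c1[C@@H]3Cn1cc(-c2ccc(C(F)(F)F)cc2)nn1`, has not yet been measured; it carries trifluoromethyl in place of fluoro on an aromatic carbon relative to compound 3, the same change seen between compound 1 and compound 2, made at the same place on the same kind of ring. Among the compounds with values here, the step that the limit leaves unreadable from compound 3 to compound 4 from compound 3 to compound 4 is expected to be as unreadable as the earlier one, because the limit of > 20000 nM in this assay, at which 3 of the 3 values shown sit, shows every value so far sitting at the same limit. Compound 4 is therefore estimated to come in around 30000 nM, most likely reported as a limit rather than a number, with a plausible span from 10000 nM to 100000 nM.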

Compound 4, half-maximal inhibitory concentration: > 20000 nM
Compound 4 was reported as a limit (the forecaster's own chance of this, stated with the estimate: 85%); the middle value lies beyond the limit too.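

In this assay compound 4 gives > 20000 nM, which is a limit of the assay and not a number. Within the data shown here, the change from compound 3 to compound 4, trifluoromethyl in place of fluoro, therefore gives no step that can be read. The compounds shown leave open how strongly each one acts and whether the core or the ring substituent makes any difference, with every value sitting at one limit: the limit of > 20000 nM in this assay, at which 4 of the 4 values shown sit.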